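This account rests on a few compounds, and the source may have more. Where it says the series, first, only, none or still open, it means among the compounds named here.

In an ADME assay on RAW264.7 cells (Mus musculus) for cytotoxicity, read by neutral red uptake, with a stated time of 24 h (on this read-out lower numbers stand for higher toxicity in this test and higher numbers for lower toxicity in this test), compound 3 (`O=C(CN1C(=O)S/C(=C\c2ccc(C(F)(F)F)cc2)C1=O)NOCc1ccccc1`) gives > 128000 nM and this is a limit of the assay, not a number. Compound 1 (`O=C(CN1C(=O)S/C(=C\c2ccccc2)C1=O)NOCc1ccccc1`) gives > 128000 nM and this too is a limit. Compound 2 (`C=CCONC(=O)CN1C(=O)S/C(=C\c2ccccc2)C1=O`) gives > 128000 nM and this is again a limit. Compound 3 therefore has no exact position among these compounds, and what is known so far is the limit of > 128000 nM in this assay, at which 3 of the 3 values shown sit, and nothing finer.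

Compound 4 (`C=CCONC(=O)CN1C(=O)S/C(=C\c2ccc(C(F)(F)F)cc2)C1=O`) comes from compound 3 by a single change in the side chain: vinyl in place of phenyl on a saturated chain carbon bound to an oxygen and in short, benzyloxy becomes allyloxy. The same swap has been measured once, and it gave a step that the two limits leave unreadable from compound 1 to compound 2 and so offers no size to carry over. The other measured change, trifluoromethyl in place of hydrogen on an aromatic carbon, gave a step that the two limits leave unreadable from compound 1 to compound 3 as well. Neither step shows any readable move towards higher toxicity in this test, so no step beyond the usual scatter is expected in either direction. The expected outcome is a number no higher from compound 3 to compound 4 (the limit leaves the size open) in this assay and this remains an estimate. For compound 4 the estimated value is 128000 nM with an expected range from 70000 nM to 256000 nM and the assay will most likely report only a limit.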

Compound 4, half-maximal cytotoxic concentration: > 128000 nM
Compound 4: a limit, no number; the forecaster's own chance of this, stated with the estimate: 85%; the middle value lies on the limit itself.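

Neither the step from compound 3 to compound 4 nor the step from compound 2 to compound 4 can be read, because compound 1, compound 2, compound 3 and compound 4 all end at the same limit rather than at a number: the limit of > 128000 nM in this assay, at which 4 of the 4 values shown sit.

The compounds shown leave open whether they differ at all in this assay, and at what concentration, if any, each would become toxic.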